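The compounds below may be only part of what the source reports. "The series", "measured", "known", "first", "only" and "open" are said of these compounds alone.

Measured compounds:
Compound 1, `COc1ccc(/C=C\C(=O)O)c(OCc2cn(-c3ccc(CO)cc3)nn2)c1CC=C(C)C` – "not determined" (no result reported) in a functional assay on A549 cells (Homo sapiens) for cytotoxicity, read by MTT assay, with a stated time of 24 h; a lower number here means a stronger inhibitor, a higher number a weaker inhibitor.
Compound 2, `COc1ccc(/C=C\C(=O)O)c(OCc2cn(-c3nc4ccccc4s3)nn2)c1CC=C(C)C` – 42100 nM in this assay.

Compound 2 holds the only number shown in this assay; compound 1 carries no result there, so nothing can be said about how the two compare. Taken on its own, the value of compound 2 describes a weak inhibitor of cell growth in this assay.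

Compound 3, `COc1ccc(/C=C\C(=O)O)c(OCc2cn(-c3ccccc3C#N)nn2)c1CC=C(C)C`, differs from compound 2 in one place: 2-cyanophenyl in place of 1,3-benzothiazol-2-yl on an aromatic nitrogen. The shared core, with its methoxy group, its prenyl chain and its acrylic acid, stays untouched.

Among the compounds with values here, no step between two measured compounds is available to show how such an exchange on the aromatic nitrogen shifts the read-out in this assay. With a single measured point and no comparison, the most defensible expectation is a change that stays within the usual scatter. The estimated step from compound 2 to compound 3 in this assay is therefore a 1.2-fold higher number from compound 2 to compound 3 (0.07 log units; within the scatter). Compound 3 is expected to give about 50000 nM in this assay, with a likely range from 15000 nM to 150000 nM.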

Compound 3, half-maximal inhibitory concentration: 38600 nM
Beside the measured number, compound 3's estimate is 1.3-fold (0.11 log units) above it; measured number inside the range.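

In this assay the exchange of 1,3-benzothiazol-2-yl for 2-cyanophenyl on the aromatic nitrogen gives a 1.1-fold lower number from compound 2 to compound 3 (0.04 log units; within the scatter) and so shows no real difference between the two compounds. Within the data shown here, this is the first readable comparison at this position, and the exchange is a sizeable one on paper: a five-membered aromatic ring holding sulfur and nitrogen leaves, a nitrile enters, and the group goes from 2 hydrogen-bond acceptors to 1, yet both compounds read as weak inhibitors of cell growth. No measured evidence is available to explain this outcome.

Two groups at this position are too few to show whether the read-out is insensitive to this position in general, so a group of a different kind, such as an amine or a longer carbon chain, could still behave differently on the same nitrogen. The compounds shown also leave open what happens in this assay when the shared core itself changes, for example when a methyl ester takes the place of the carboxylic acid or a shorter chain takes the place of the prenyl chain.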